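Swapping an aryl group on two closely related cores

The compounds below may be only part of what the source reports. "The series", "measured", "known", "first", "only" and "open" are said of these compounds alone.

Compound 1 `COc1cccc(-c2cc(C(=O)Nc3ccc(Oc4ccnc5cc(OCCCN6CCCCC6)c(OC)cc45)c(F)c3)c3cc(F)ccc3n2)c1` and compound 3 `COc1cccc(-c2cc(C(=O)Nc3ccc(Oc4ccnc5cc(OCCCN6CCC(C)CC6)c(OC)cc45)c(F)c3)c3cc(F)ccc3n2)c1` share most of their structure; the difference between their cores is methyl in place of hydrogen on a saturated ring carbon, and in a functional assay on MKN-45 cells (Homo sapiens) for cytotoxicity, read by MTT assay, with a stated time of 72 h (on this read-out higher numbers stand for weaker inhibition and lower numbers for stronger inhibition), compound 1 gives 690 nM while compound 3 gives 730 nM, a step of a 1.1-fold higher number from compound 1 to compound 3 (0.02 log units; within the scatter). Compound 2 `COc1cc2c(Oc3ccc(NC(=O)c4cc(-c5ccc(C)cc5)nc5ccc(F)cc45)cc3F)ccnc2cc1OCCCN1CCCCC1` carries the change 4-methylphenyl in place of 3-methoxyphenyl on an aromatic carbon and gives 170 nM, so the step is a 4.1-fold lower number from compound 1 to compound 2 (0.61 log units; beyond the scatter). Compound 4 `COc1cc2c(Oc3ccc(NC(=O)c4cc(-c5ccc(C)cc5)nc5ccc(F)cc45)cc3F)ccnc2cc1OCCCN1CCC(C)CC1` carries the same change on the core of compound 3, namely (4-methylphenyl in place of 3-methoxyphenyl on an aromatic carbon), and the place lines read alike. Within the data shown here, because the core difference made only the step of a 1.1-fold higher number from compound 1 to compound 3 (0.02 log units; within the scatter), compound 4 is expected to move from compound 3 by about a 4.1-fold lower number from compound 3 to compound 4 (0.61 log units; beyond the scatter), matching the earlier step. Compound 4 is therefore estimated at 180 nM, between 90 nM and 360 nM.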

Compound 4, half-maximal inhibitory concentration: 260 nM
Compound 4: the middle estimate sits 1.4-fold (0.16 log units) below what was measured; measured number inside the range.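

Putting 4-methylphenyl in place of 3-methoxyphenyl gives a 2.8-fold lower number from compound 3 to compound 4 (0.45 log units; beyond the scatter) in this assay, so the change carries to the second core with a step of similar size: the same change on two cores in this assay, a 4.1-fold lower number (0.61 log units; beyond the scatter) from compound 1 to compound 2 and a 2.8-fold lower number (0.45 log units; beyond the scatter) from compound 3 to compound 4, 1.4-fold (0.16 log units) apart, within the scatter of two such steps. Methyl in place of hydrogen on a saturated ring carbon gives a 1.5-fold higher number from compound 2 to compound 4 (0.18 log units; within the scatter), which also agrees with its earlier step: the same change on two cores in this assay, a 1.1-fold higher number (0.02 log units; within the scatter) from compound 1 to compound 3 and a 1.5-fold higher number (0.18 log units; within the scatter) from compound 2 to compound 4, 1.4-fold (0.16 log units) apart, within the scatter of two such steps. These four compounds show the two changes adding up simply within this small set, but they do not show why, or whether this would hold on any other core.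

The aryl swap alters both the substituent and its place on the ring, so a 3-methylphenyl or 4-methoxyphenyl group would be needed to separate the two. Also open, on these data alone, is whether the step holds with a 4-chlorophenyl group, or with a morpholine at the end of the chain.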